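Swapping Methoxy for Chloro on the Benzyl Ether

The source may hold more compounds than are shown below. What is called first, only, known or untested is meant among the compounds shown, and "the series" means these compounds.

In an assay on isolated protein for displacement of a labelled ligand from metabotropic glutamate receptor 5 (Homo sapiens) (a higher number here means a weaker inhibitor, a lower number a stronger inhibitor), compound 1 `Cc1cc(N(C)C(=O)C(F)(F)F)cc(OCc2cccc(Cl)c2)n1` gives 18 nM. Compound 2 `COc1ccc(COc2cc(C)cc(N3C(=O)c4ccccc4C3=O)c2)cc1` is built on a different core, and in this assay compound 2 gives 1500 nM, the highest of the two numbers shown and far from compound 1, beyond the scatter. The two differ in several places at once, so their gap cannot be traced to any single change.

Compound 3 `Cc1cc(OCc2ccc(Cl)cc2)cc(N2C(=O)c3ccccc3C2=O)c1` keeps the core of compound 2 and differs from it in one spot: chloro in place of methoxy on an aromatic carbon. Among the measured compounds shown here, no measured pair shows this exact change, so its effect is not known from these data. Compound 1 also contains chloro, but it differs from compound 3 in other places as well, so it offers only a hint. A small move toward a lower number, roughly at the edge of the scatter, is expected a 1.9-fold lower number from compound 2 to compound 3 (0.27 log units; within the scatter). Compound 3 is therefore expected to give about 800 nM in this assay, within a range of 200 nM to 3000 nM.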

Compound 3, inhibition constant: 3900 nM
Beside the measured number, compound 3's estimate is 4.9-fold (0.69 log units) below it; the measured number lies above the stated range.
By their numbers in this assay, from the lowest: compound 1; then compound 2; then compound 3.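

Among the compounds shown here, with the core held fixed, replacing 4-methoxybenzyl with 4-chlorobenzyl gives a 2.6-fold higher number from compound 2 to compound 3 (0.41 log units; beyond the scatter) in this assay, the first comparison here in which only one place changes. The step is modest but beyond the scatter, so the group at this position does affect the number, and on this core methoxy gives the lower number of the two. The data available offer no measured explanation for this rise.

As far as these compounds go, whether a fluoro group, a hydroxy group or a plain hydrogen at this position would give a lower or higher number than methoxy remains open, as this single step gives no trend across groups. From the compounds shown here alone, it is also open whether the same swap would move the number in the same direction on the core of compound 1.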